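Series notes: trifluoromethyl to hydrogen on the aryl ring

The compounds below may be only part of what the source reports. "The series", "measured", "known", "first", "only" and "open" are said of these compounds alone.

In a functional assay on MCF7 cells (Homo sapiens) for antiproliferative activity, read by MTT assay, with a stated time of 48 h (a higher number here means a weaker inhibitor, a lower number a stronger inhibitor), compound 2 `COC(=O)/C(=C/c1ccccc1)CN1C(=O)[C@@H](OC)[C@H]1c1ccccc1C(F)(F)F` gives no result reported, so it has no single number in this assay. Among the measured compounds shown here, the one measured analogue, compound 1 `CCOC(=O)/C(=C/c1ccccc1)CN1C(=O)[C@@H](OC)[C@H]1c1ccc(Cl)cc1`, gives 12700 nM in this assay, a weak result. Compound 3 `COC(=O)/C(=C/c1ccccc1)CN1C(=O)[C@@H](OC)[C@H]1c1ccccc1` differs from compound 2 by hydrogen in place of trifluoromethyl on an aromatic carbon. For the measured compounds named here, no measured pair of this kind exists in the set, so no computed step is available; the change is expected to shift this assay little, most likely within the scatter, in either direction. Given the weak value of compound 1 at 12700 nM, compound 3 is expected near 15000 nM in this assay, estimated between 4000 nM and 50000 nM.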

Compound 3, half-maximal inhibitory concentration: 12900 nM
For compound 3 the middle estimate is 1.2-fold (0.07 log units) above the measured one, within the range that was stated.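

Among the compounds shown here, compound 2 has no single number in this assay so no step from it to compound 3 can be read. The compounds shown leave open how trifluoromethyl and hydrogen compare on this aromatic carbon in this assay and no evidence bears on the result.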